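A few compounds are considered here, and "the series" means these few. Any claim that something is new, unique, unknown or untested is made for them only; others in the source may bear on it.

Compound 1 `Nc1nc(SCc2ccccc2)nc2c1nc(O)n2Cc1ccccc1` and compound 2 `CCCCCSc1nc(N)c2nc(O)n(Cc3ccccc3)c2n1` share a core with compound 3 `COc1nc2c(N)ncnc2n1Cc1ccccc1` and compound 4 `Nc1ncnc2c1nc(I)n2Cc1ccccc1`. In a functional assay (spleen, spleen) for activation, with Mus musculus as the target (a lower number here means that less compound is needed, a higher number that more compound is needed for the effect), compound 1 gives 0.1 uM. In this assay compound 2 gives 10 uM. Within the data shown here, the one change measured between them, a 100-fold higher number from compound 1 to compound 2 (2.00 log units; beyond the scatter), sits on the sulfur-bound chain, a different part of the molecule from the one that changes here. For compound 3 this assay reports only a limit, > 10 uM, so compound 3 stands at the limit of > 10 uM in this assay, at which 1 of the 3 values shown sits, rather than at a number.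

Compound 4 differs from compound 3 in one place: iodo in place of methoxy on an aromatic carbon. Among the measured compounds shown here, no measured step touches this position, so the measured step gives no direct guide to its size or direction. Starting from a limit, the expectation is that compound 4 stays near it, with a step of a number no higher from compound 3 to compound 4 (the limit leaves the size open) expected. Compound 4 is therefore estimated at 10 uM, within a range from 1 uM to 100 uM, with a fair chance that only a limit is reported again.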

Compound 4, minimum effective concentration: > 10 uM
Compound 4 was reported as a limit; the forecaster's own chance of this, stated with the estimate: 55%; the middle value lies on the limit itself.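

Compound 3 and compound 4 both stop at a limit, so no step between them can be read: the limit of > 10 uM in this assay, at which 2 of the 4 values shown sit.

The compounds shown leave open how iodo and methoxy compare on this aromatic carbon, and how much compound either of these two would need for the effect.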